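Sulfonamide series at the serotonin-6 receptor: notes on compound 4

The compounds below may be only part of what the source reports. "The series", "measured", "known", "first", "only" and "open" are said of these compounds alone.

Measured so far:
compound 1, `COc1ccc(S(=O)(=O)Nc2cccc(Br)c2)cc1N1CCNCC1`: 1.26 nM
compound 2, `COc1ccc(S(=O)(=O)Nc2ccc(Cl)c(Cl)c2)cc1N1CCNCC1`: 2.51 nM
compound 3, `COc1ccc(S(=O)(=O)Nc2c(F)cc(Br)cc2F)cc1N1CCNCC1`: 158 nM

In an assay on isolated protein for binding affinity to 5-hydroxytryptamine receptor 6 (Homo sapiens) (on this read-out higher numbers stand for weaker inhibition and lower numbers for stronger inhibition), compound 3 gives the highest number of the three, with a 63-fold higher number from compound 2 to compound 3 (1.80 log units; beyond the scatter) and a 130-fold higher number from compound 1 to compound 3 (2.10 log units; beyond the scatter), while a 2.0-fold higher number from compound 1 to compound 2 (0.30 log units; within the scatter).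

Compound 4, `COc1ccc(S(=O)(=O)Nc2cc(Cl)cc(Br)c2Cl)cc1N1CCNCC1`, differs from compound 3 in one place: 3-bromo-2,5-dichlorophenyl in place of 4-bromo-2,6-difluorophenyl on a sulfonamide nitrogen. Among the measured compounds shown here, the steps that bear on this are the two into compound 3, both large and both beyond the scatter, each from a phenyl bearing only bromine or chlorine to the 4-bromo-2,6-difluorophenyl. Compound 4 returns to a phenyl carrying only bromine and chlorine, which stands closer to compounds 1 and 2 than to compound 3, so a lower number than compound 3 is expected in this assay, though probably not all of the way back. The expected step is a 13-fold lower number from compound 3 to compound 4 (1.12 log units; beyond the scatter). For compound 4 the estimate is 12 nM, with a range from 2.5 nM to 60 nM.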

Compound 4, inhibition constant: 2 nM
Compound 4: middle estimate off by 6.0-fold (0.78 log units), on the high side, outside the stated range (below it).
By their numbers in this assay, from the lowest: compounds 1, 4 and 2 (each within the scatter of the next); then compound 3.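

Replacing the 4-bromo-2,6-difluorophenyl with the 3-bromo-2,5-dichlorophenyl on the sulfonamide nitrogen restores the level of the series in this assay (a 79-fold lower number from compound 3 to compound 4 (1.90 log units; beyond the scatter)), with the count of ring heavy atoms unchanged. A phenyl carrying three halogens can therefore match the simpler rings, as both remaining steps lie within the scatter (a 1.3-fold lower number from compound 2 to compound 4 (0.10 log units; within the scatter); a 1.6-fold higher number from compound 1 to compound 4 (0.20 log units; within the scatter)). No available evidence accounts for the gap between these two rings.

On these data alone, whether one fluorine alone in compound 3 carries the loss remains open, as does whether an amine or a carboxylic acid on this phenyl would hold the level.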